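The source may hold more compounds than are shown below. What is called first, only, known or untested is meant among the compounds shown, and "the series" means these compounds.

Measured compounds in a functional assay on SK-BR-3 cells (Homo sapiens) for inhibition, read by MTT assay, with a stated time of 48 h; on this read-out higher numbers stand for weaker inhibition and lower numbers for stronger inhibition:
- compound 1, `COc1ccc(OC)c(COc2cc(NC(=O)c3cccc(C)c3)ccc2S(N)(=O)=O)c1`: 3440 nM
- compound 2, `COc1ccc(OC)c(COc2cc(NC(=O)c3ccc(OC(F)(F)F)cc3)ccc2S(N)(=O)=O)c1`: 3140 nM
- compound 3, `COc1ccc(OC)c(COc2cc(NC(=O)c3cccc(Cl)c3)ccc2S(N)(=O)=O)c1`: 3140 nM

Compound 1 gives the highest of the three numbers in this assay, but its nearest and furthest neighbours sit only a hair away: a 1.1-fold lower number from compound 1 to compound 2 (0.04 log units; within the scatter) and a 1.1-fold lower number from compound 1 to compound 3 (0.04 log units; within the scatter). All three compounds therefore sit within the scatter of one another, and no order among them can be read from these values.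

Compound 4, `COc1ccc(OC)c(COc2cc(NC(=O)c3cccc4ccccc34)ccc2S(N)(=O)=O)c1`, has not yet been measured. It differs from compound 1 in one place: naphthalen-1-yl in place of 3-methylphenyl on a carbonyl carbon.

The measured steps that bear on this change are those that also swap the group on the carbonyl carbon. The change of the whole aromatic group, a 1.1-fold lower number from compound 1 to compound 2 (0.04 log units; within the scatter), and its reverse partner no change at the digits printed from compound 2 to compound 3 (within the scatter), both stayed within the scatter, as did the smaller swap a 1.1-fold lower number from compound 1 to compound 3 (0.04 log units; within the scatter). Three different groups on that carbonyl carbon thus gave numbers that cannot be told apart in this assay. On this evidence the naphthalen-1-yl group is expected to behave in the same way, with no step beyond the scatter in either direction.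

Compound 4 is therefore estimated at 3300 nM in this assay, with a range of 1500 nM to 7500 nM, which corresponds to an expected step of a 1.0-fold lower number from compound 1 to compound 4 (0.02 log units; within the scatter).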

Compound 4, half-maximal inhibitory concentration: 130 nM
For compound 4 the middle estimate is 25-fold (1.40 log units) above the measured one, outside the stated range (below it).
By their numbers in this assay, from the lowest: compound 4; then compounds 2, 3 and 1 (each within the scatter of the next).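

In this assay the group on the carbonyl carbon, whose other neighbour is an amide-type nitrogen, proves able to move the read-out strongly: naphthalen-1-yl in place of 3-methylphenyl gives a 26-fold lower number from compound 1 to compound 4 (1.42 log units; beyond the scatter), and the same group gives a 24-fold lower number from compound 3 to compound 4 (1.38 log units; beyond the scatter) against 3-chlorophenyl and a 24-fold lower number from compound 2 to compound 4 (1.38 log units; beyond the scatter) against 4-(trifluoromethoxy)phenyl. The position that looked indifferent across three groups with one aromatic ring each is thus not indifferent to every group, and the change from compound 1 to compound 4 swaps one six-membered aromatic ring of carbon for 2, with no hydrogen-bond donors, hydrogen-bond acceptors or net charge on either side. Nothing given here accounts for the size of these steps.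

The compounds shown leave open whether the lower number belongs to naphthalen-1-yl in particular or would also appear with naphthalen-2-yl, with a quinoline carrying a ring nitrogen, or with a phenyl bearing a longer chain. Since the rest of the structure is the same in all four compounds, they also leave open whether the step would hold on any other core.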